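Bromopyridinyl ether variation on a triazolylbenzamide piperidine core

This account rests on a few compounds, and the source may have more. Where it says the series, first, only, none or still open, it means among the compounds named here.

Measured so far in an assay on CHO-K1 cells for displacement of a labelled ligand from Orexin/Hypocretin receptor type 1 (Homo sapiens), read by radioligand binding; a lower number here means a stronger inhibitor, a higher number a weaker inhibitor:
compound 1 `CCc1ccnc(O[C@@H]2CC[C@@H](C)N(C(=O)c3ccccc3-n3nccn3)C2)c1` gives 57 nM
compound 2 `C#Cc1ccnc(O[C@@H]2CC[C@@H](C)N(C(=O)c3ccccc3-n3nccn3)C2)c1` gives 49 nM
compound 3 `Cc1cccc(O[C@@H]2CC[C@@H](C)N(C(=O)c3ccccc3-n3nccn3)C2)n1` gives 12 nM

Compound 3 holds the lowest number of the three in this assay, standing beyond the scatter from both others: a 4.8-fold lower number from compound 1 to compound 3 (0.68 log units; beyond the scatter) and a 4.1-fold lower number from compound 2 to compound 3 (0.61 log units; beyond the scatter). Between compound 1 and compound 2 the step is a 1.2-fold lower number from compound 1 to compound 2 (0.07 log units; within the scatter), so those two cannot be told apart.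

Compound 4 `C[C@@H]1CC[C@@H](Oc2cc(Br)ccn2)CN1C(=O)c1ccccc1-n1nccn1` is not yet measured. It differs from compound 3 in one place: 4-bromopyridin-2-yl in place of 6-methylpyridin-2-yl on an oxygen on a saturated carbon. The 4-bromopyridin-2-yl of compound 4 resembles the 4-ethylpyridin-2-yl of compound 1 and the 4-ethynylpyridin-2-yl of compound 2 more than the 6-methylpyridin-2-yl of compound 3. Going by the values given here, the steps that bear on this change are those from compound 1 and compound 2 to compound 3, both modest and both lowering the number. Going the other way, compound 4 is expected to land near compounds 1 and 2, a step of a 3.8-fold higher number from compound 3 to compound 4 (0.57 log units; beyond the scatter) in this assay. For compound 4 the estimate is 45 nM, within 18 nM to 110 nM.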

Compound 4, inhibition constant: 130 nM
The estimate for compound 4 lay 2.9-fold (0.46 log units) below the measured number; measured number outside the range, above it.
By their numbers in this assay, from the lowest: compound 3; then compounds 2 and 1 (each within the scatter of the next); then compound 4.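

In this assay, going by these compounds alone, the change from 6-methylpyridin-2-yl to 4-bromopyridin-2-yl on the oxygen gives an 11-fold higher number from compound 3 to compound 4 (1.03 log units; beyond the scatter) and is the only large step in the set, so the choice of aryl group here can shift the number further than the earlier steps showed. The earlier pair with ethyl and ethynyl could not be told apart, yet the group on that aromatic carbon does matter: bromo gives a 2.7-fold higher number from compound 2 to compound 4 (0.42 log units; beyond the scatter) and a 2.3-fold higher number from compound 1 to compound 4 (0.36 log units; beyond the scatter) as modest steps beyond the scatter.

Compound 3 differs from the others in both its group and where that group sits, so the two effects cannot be separated without 4-methylpyridin-2-yl or 6-bromopyridin-2-yl. As far as these compounds go, it also remains open how an amine on the same aromatic carbon would compare. Nothing available here accounts for these steps.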